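Swapping the terminal ester group for a tertiary amide

This account rests on a few compounds, and the source may have more. Where it says the series, first, only, none or still open, it means among the compounds named here.

Measured compounds in an ADME assay (liver) for pharmacokinetics, with Liver microsome (Rattus norvegicus) as the target, using microsomes; a higher number here means that the compound lasts longer, a lower number that the compound disappears faster:
compound 1 `CCCOC(=O)/C=C/c1ccc(NC(=O)C2(NC(=O)c3ccc4c(C5CCCC5)c(-c5ncc(Cl)cn5)n(C)c4c3)CCC2)cc1OCC` gives 0.35 h
compound 2 `CCOc1cc(NC(=O)C2(NC(=O)c3ccc4c(C5CCCC5)c(-c5ncc(Cl)cn5)n(C)c4c3)CCC2)ccc1/C=C/C(=O)OCCOc1ccccc1` gives 16.5 h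
compound 3 `CCOc1cc(NC(=O)C2(NC(=O)c3ccc4c(C5CCCC5)c(-c5ncc(Cl)cn5)n(C)c4c3)CCC2)ccc1/C=C/C(=O)OCC(=O)OCc1ccc(Cl)cc1` gives 11.4 h

Compound 3 stands second highest of the three numbers in this assay, with compound 2 closest to it and compound 1 far below it. The step of a 47-fold higher number from compound 1 to compound 2 (1.67 log units; beyond the scatter) and the step of a 33-fold higher number from compound 1 to compound 3 (1.51 log units; beyond the scatter) were both large, while the step of a 1.4-fold lower number from compound 2 to compound 3 (0.16 log units; within the scatter) stayed within the scatter. Compound 4 `CCOc1cc(NC(=O)C2(NC(=O)c3ccc4c(C5CCCC5)c(-c5ncc(Cl)cn5)n(C)c4c3)CCC2)ccc1/C=C/C(=O)OCC(=O)N(C)C(C)C` has not yet been measured in this assay. It differs from compound 3 in one place: isopropyl(methyl)amino in place of (4-chlorobenzyl)oxy on a carbonyl carbon. Among the compounds with values here, none of the measured steps changes the atom bound to this carbonyl carbon, so no step bears on it directly; the only guidance is that the two compounds with the longer terminus, compound 2 and compound 3, sit close together. Compound 4 is therefore expected to show a step of a 1.4-fold lower number from compound 3 to compound 4 (0.15 log units; within the scatter), not clearly beyond the scatter. The estimate for compound 4 is 8 h, within a range from 2.5 h to 25 h.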

Compound 4, half-life: 0.267 h
For compound 4 the middle estimate is 30-fold (1.48 log units) above the measured one; the whole stated range lies above it.
By their numbers in this assay, from the lowest: compounds 4 and 1 (each within the scatter of the next); then compounds 3 and 2 (each within the scatter of the next).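

In this assay, what sits on this carbonyl carbon matters greatly: isopropyl(methyl)amino in place of (4-chlorobenzyl)oxy gives a 43-fold lower number from compound 3 to compound 4 (1.63 log units; beyond the scatter), so a longer terminus does not by itself carry a high number. The comparison with the other long terminus agrees, at a 62-fold lower number from compound 2 to compound 4 (1.79 log units; beyond the scatter), while a 1.3-fold lower number from compound 1 to compound 4 (0.12 log units; within the scatter) puts compound 4 within the scatter of the short-chain compound 1, making compound 4 the listed exception to the pairing of longer terminus and high number. No measurement shown here accounts for this drop.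

The change swaps the oxygen for a nitrogen and removes the aromatic ring in a single step, and the two remain unseparated. A (4-chlorobenzyl)amino group or a methoxy group on the same carbonyl carbon would tell them apart.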